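Chloropurine benzyl chlorides: cytotoxicity on OVCAR-8 cells

The compounds below may be only part of what the source reports. "The series", "measured", "known", "first", "only" and "open" are said of these compounds alone.

Measured compounds:
compound 1, `ClCc1ccc(Cn2cnc3c(Cl)ncnc32)cc1`: 3020 nM
compound 2, `ClCc1cccc(Cn2cnc3ncnc(Cl)c32)c1`: 3090 nM
compound 3, `ClCc1cccc(Cn2cnc3c(Cl)nc(Cl)nc32)c1`: 1820 nM

In a functional assay on OVCAR-8 cells (Homo sapiens) for cytotoxicity, read by sulforhodamine B assay, with a stated time of 48 h (on this read-out lower numbers stand for stronger inhibition of growth and higher numbers for weaker inhibition of growth), compound 2 gives 3090 nM, the highest of the three numbers. Compound 1 gives 3020 nM, a value that sits within the scatter of compound 2, so no order between the two can be read. Among the measured compounds shown here, compound 3 gives 1820 nM; its gap to compound 2 also stays within the scatter, and compound 3 carries a second chloro on a core arranged differently from that of compound 2, so its value offers no direct step.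

Compound 4, `ClCc1cccc(Cn2cnc3nc(Cl)nc(Cl)c32)c1`, has not yet been measured in this assay. It differs from compound 2 by chloro in place of hydrogen on an aromatic carbon. For the measured compounds named here, no measured pair shows this change on the core of compound 2. Going by the values given here, all three numbers so far lie close together, and the one dichloro analogue, compound 3, gives 1820 nM within the scatter of compound 2, so no step beyond the scatter is expected. Compound 4 is expected to give about 2200 nM, with a range from 900 nM to 5500 nM, which means an expected step of a 1.4-fold lower number from compound 2 to compound 4 (0.15 log units; within the scatter).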

Compound 4, concentration for 50% growth inhibition: 9330 nM
The estimate for compound 4 lay 4.2-fold (0.63 log units) below the measured number; measured number outside the range, above it.
By their numbers in this assay, from the lowest: compounds 3, 1 and 2 (each within the scatter of the next); then compound 4.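

In this assay the chloro in place of hydrogen on this aromatic carbon, between two ring nitrogen atoms, gives a 3.0-fold higher number from compound 2 to compound 4 (0.48 log units; beyond the scatter) and so moves towards weaker inhibition of growth. The earlier compounds shown here showed no step beyond the scatter, whereas this pair shows that, on the core of compound 2, the position is sensitive to this single change. This rests on one pair on one core, and no measurement at hand offers an explanation for the step.

Open, from the compounds shown here alone, is how an amine, a methoxy group or a longer chain would read at this position in place of chloro. Also open, going by these compounds, is whether the same change gives a step of similar size and direction on the core of compound 1.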